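A few compounds are considered here, and "the series" means these few. Any claim that something is new, unique, unknown or untested is made for them only; others in the source may bear on it.

In a functional assay on the whole organism (Tail, strain ICR) with Mus musculus as the target, in the tail flick test, with a stated time of 150 min, at a dose of 25 umol/kg by the oral route (on this read-out lower numbers stand for a weaker effect and higher numbers for a stronger effect at the one dose given), compound 1 `C[C@H](NC(=O)CN(c1nc(Cl)nc2[nH]cnc12)C1CC1)C(=O)OCc1ccccc1` gives 23%, compound 2 `C[C@@H](O)[C@H](NC(=O)CN(c1nc(Cl)nc2[nH]cnc12)C1CC1)C(=O)OCc1ccccc1` gives 12.8%, and compound 3 `O=C(OCc1ccccc1)[C@@H]1CCCN1C(=O)CN(c1ncnc2c1ncn2C1CCCCO1)C1CC1` gives 7.85%. Compound 2 thus stands second highest of the three numbers: its nearest neighbour is compound 3, within the scatter, while compound 1 lies beyond the scatter above it. Compound 4 `NCCCC[C@H](NC(=O)CN(c1nc(Cl)nc2[nH]cnc12)C1CC1)C(=O)OCc1ccccc1` has not yet been measured in this assay. It differs from compound 2 in one place: 4-aminobutyl in place of 1-hydroxyethyl on a saturated chain carbon bound to an amide-type nitrogen and a carbonyl carbon. Going by the values given here, the only measured step at this same place, a number 10.2 percentage points lower from compound 1 to compound 2 (beyond the scatter), shows that exchanging the group on the saturated chain carbon bound to an amide-type nitrogen and a carbonyl carbon can move the number by a modest amount. That step does not involve 4-aminobutyl, so it sets a likely size but no direction. Compound 4 is therefore expected to show a number 1.2 percentage points higher from compound 2 to compound 4 (within the scatter), a step within the scatter. The estimate for compound 4 is 14%, with a range from 3% to 28%.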

Compound 4, a percentage reported as activity, at one dose (the size of the read-out at that dose, not a potency): 9.88%
Beside the measured number, compound 4's estimate is 4.1 percentage points above it; the range from low to high includes it.
By their numbers in this assay, from the lowest: compounds 3, 4 and 2 (each within the scatter of the next); then compound 1.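

In this assay, placing 4-aminobutyl in place of 1-hydroxyethyl on a saturated chain carbon bound to an amide-type nitrogen and a carbonyl carbon gives a number 2.9 percentage points lower from compound 2 to compound 4 (within the scatter), so this exchange leaves the read-out unresolved. The change from methyl to the longer amine-bearing chain gives a number 13.1 percentage points lower from compound 1 to compound 4 (beyond the scatter), so a second group at this position, besides 1-hydroxyethyl, stands apart from methyl in the same direction, and among these three compounds only the methyl compound is set apart. No measured evidence explains this result.

As far as these compounds go, it remains open whether a carboxylic acid or a simple unsubstituted alkyl chain on this carbon would group with the two lower compounds or with the methyl compound. A shorter amine-bearing chain at the same place also remains to be placed.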